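The compounds below may be only part of what the source reports. "The series", "measured", "known", "first", "only" and "open" are said of these compounds alone.

Measured compounds:
compound 1 `CCN(CC)c1nc(Nc2cccc(Cl)c2)nc(OC(C(F)(F)F)C(F)(F)F)n1`, in an assay on cells for activation of Cystic fibrosis transmembrane conductance regulator (Homo sapiens), read by fluorescence, with stated times of 10 min and 12 s (on this read-out lower numbers stand for an effect already at smaller amounts and higher numbers for an effect only at larger amounts of compound), compound 1 gives 2800 nM;
compound 2 `CCN(CC)c1nc(Nc2ccc(F)cc2)nc(OC(C(F)(F)F)C(F)(F)F)n1`, in this assay compound 2 gives 700 nM.

Compound 1 stands highest of the two numbers measured; its nearest neighbour is compound 2, reached by a 4.0-fold lower number from compound 1 to compound 2 (0.60 log units; beyond the scatter), a change on the nitrogen on the aromatic ring rather than on the ether oxygen.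

Compound 3 `CCN(CC)c1nc(Nc2cccc(Cl)c2)nc(OCC(F)(F)C(F)F)n1` differs from compound 1 in one place: 2,2,3,3-tetrafluoropropyl in place of 2,2,2-trifluoro-1-(trifluoromethyl)ethyl on an oxygen on an aromatic ring. Among the measured compounds shown here, no measured step touches this ether position; the only step seen, from compound 1 to compound 2, concerns the other side of the shared core and so gives no direct guidance on the size or direction of the change to compound 3. In this assay compound 3 is therefore expected to sit close to compound 1, with no step beyond the scatter, giving an expected step of a 1.1-fold higher number from compound 1 to compound 3 (0.03 log units; within the scatter). Compound 3 is estimated at 3000 nM, within a range of 900 nM to 10000 nM.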

Compound 3, half-maximal effective concentration: 5400 nM
Estimate against measurement, compound 3: 1.8-fold (0.26 log units) below, and the stated range covers the measured number.
By their numbers in this assay, from the lowest: compound 2; then compounds 1 and 3 (each within the scatter of the next).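

In this assay, the ether position now has a measured step of its own: a 1.9-fold higher number from compound 1 to compound 3 (0.29 log units; within the scatter). Exchanging 2,2,2-trifluoro-1-(trifluoromethyl)ethyl, with nine heavy atoms including six fluorine, for 2,2,3,3-tetrafluoropropyl, with seven including four fluorine, therefore leaves compounds 1 and 3 within the scatter of each other, whereas a 4.0-fold lower number from compound 1 to compound 2 (0.60 log units; beyond the scatter) on the nitrogen side lies beyond it. Nothing available explains this result or says what the two groups do at this position.

The compounds shown leave open how a plain propyl chain on this oxygen, or an amine in place of the oxygen, would read out. They also leave open whether 2,2,3,3-tetrafluoropropyl would give a similar number alongside the 4-fluorophenyl group of compound 2.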